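Swapping trifluoromethyl for chloro on two related cores

The compounds below may be only part of what the source reports. "The series", "measured", "known", "first", "only" and "open" are said of these compounds alone.

Compound 1 `O=C(O)CNC(=O)c1c(O)c2c(n(Cc3ccc(C(F)(F)F)cc3)c1=O)CCOC2` and compound 2 `O=C(O)CNC(=O)c1c(O)c2c(n(Cc3ccc(Cl)cc3)c1=O)CCOC2` share one core and differ only by chloro in place of trifluoromethyl on an aromatic carbon. In an ADME assay on LLC-PK1 cells (Sus scrofa) for permeability, with a stated time of 3 h, tested at 1 uM (a lower number here means that the compound crosses the layer more slowly, a higher number that the compound crosses the layer faster), compound 1 gives 4 10^-6 cm/s, and compound 2 gives 3.6 10^-6 cm/s; this change made a 1.1-fold lower number from compound 1 to compound 2 (0.05 log units; within the scatter). Compound 3 `O=C(O)CNC(=O)c1c(O)c2c(n(Cc3ccc(C(F)(F)F)cc3)c1=O)COC2` is built on a second core, and the difference between the two cores is not broken down here. In this assay compound 3 gives 4.2 10^-6 cm/s. Compound 4 `O=C(O)CNC(=O)c1c(O)c2c(n(Cc3ccc(Cl)cc3)c1=O)COC2` has not yet been measured; it differs from compound 3 by chloro in place of trifluoromethyl on an aromatic carbon, the same change as between compound 1 and compound 2, made at the same place. Because the earlier step was a 1.1-fold lower number from compound 1 to compound 2 (0.05 log units; within the scatter), the step expected for compound 4 in this assay is a 1.1-fold lower number from compound 3 to compound 4 (0.04 log units; within the scatter). The estimate for compound 4 in this assay is 3.8 10^-6 cm/s, expected to fall between 2.5 10^-6 cm/s and 5.8 10^-6 cm/s.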

Compound 4, apparent permeability: 2.5 10^-6 cm/s
The estimate for compound 4 lay 1.5-fold (0.18 log units) above the measured number, within the range that was stated.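

Chloro in place of trifluoromethyl on an aromatic carbon gives, in this assay, a 1.7-fold lower number from compound 3 to compound 4 (0.23 log units; within the scatter). Set beside the earlier step, the result gives no sign that the change behaves differently on the two cores: the same change on two cores in this assay, a 1.1-fold lower number (0.05 log units; within the scatter) from compound 1 to compound 2 and a 1.7-fold lower number (0.23 log units; within the scatter) from compound 3 to compound 4, 1.5-fold (0.18 log units) apart, within the scatter of two such steps. Among the compounds shown here, this shows that, within the scatter, the step carried over from one core to the other, but with only one pair on each core it does not prove that the two steps are equal, and it says nothing about any further core.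

The compounds shown leave open what other groups would do at this place. On these data alone, whether a nitrile or an amine there would give a step beyond the scatter remains unknown.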